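A Methyl Added Where the Measured Steps Do Not Reach

A few compounds are considered here, and "the series" means these few. Any claim that something is new, unique, unknown or untested is made for them only; others in the source may bear on it.

Among the compounds with values here, compound 1 `CCc1cccc(NC(=O)c2cccc(/C=C3\CC(=O)N(c4ccccc4)C3=O)c2)c1` is the only member of this small set with a number rather than a limit: in an ADME assay on SW480 cells (Homo sapiens) for cytotoxicity, read by MTT assay, with a stated time of 72 h (a higher number here means a weaker inhibitor, a lower number a stronger inhibitor), compound 1 gives 88600 nM. Compound 2 `O=C(NCC1CCCCC1)c1cccc(/C=C2\CC(=O)N(c3ccccc3)C2=O)c1` reaches only a limit of the assay, and in this assay compound 2 gives > 100000 nM. Compound 3 `O=C(Nc1ccc(F)cc1)c1cccc(/C=C2\CC(=O)N(c3ccccc3)C2=O)c1` likewise reaches only a limit, and in this assay compound 3 gives > 100000 nM. Both sit at the limit of > 100000 nM in this assay, at which 2 of the 3 values shown sit. Every measured step exchanges the group on the amide-type nitrogen: an at least 1.1-fold higher number from compound 1 to compound 2 (0.05 log units; that floor lies within the scatter), an at least 1.1-fold higher number from compound 1 to compound 3 (0.05 log units; that floor lies within the scatter), and a step that the two limits leave unreadable from compound 2 to compound 3. Within the data shown here, compound 4 `CCc1cccc(NC(=O)c2cccc(/C=C3\CC(=O)N(c4ccc(C)cc4)C3=O)c2)c1` changes a different part of compound 1: methyl in place of hydrogen on an aromatic carbon, on a ring that none of the measured steps touches. The measured steps therefore give no direct guide, and the number for compound 1 is the only anchor. Since no step beyond the scatter appears anywhere here, the expected change is a 1.0-fold higher number from compound 1 to compound 4 (0.01 log units; within the scatter), a step within the scatter. The estimate for compound 4 is therefore 90000 nM, with a range from 50000 nM to 160000 nM, and a real chance that this assay reports only a limit for compound 4.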

Compound 4, half-maximal inhibitory concentration: 65300 nM
Estimate against measurement, compound 4: 1.4-fold (0.14 log units) above, and the stated range covers the measured number.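

Within the data shown here, compound 4 gives the only readable step away from the amide-type nitrogen: with phenyl turned into 4-methylphenyl, this assay shows a 1.4-fold lower number from compound 1 to compound 4 (0.13 log units; within the scatter). On this single example, then, a methyl placed on an aromatic carbon, para to a large group, shifts the number no more than repeat measurements of one compound would. Compound 4 also gives a real number, so this change can be sized, whereas the steps to the other compounds run into a limit: the limit of > 100000 nM in this assay, at which 2 of the 4 values shown sit.

One methyl says little about how much this position tolerates. From the compounds shown here alone, whether an amine, a carboxylic acid or a longer chain at the same place would produce a step beyond the scatter stays open, as does the effect of a methyl elsewhere on this ring.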